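The compounds below may be only part of what the source reports. "The series", "measured", "known", "first", "only" and "open" are said of these compounds alone.

Working notes on the series. Compound 3 `COc1ccc2nc(-c3ccc(-n4c(C)ccc4-c4ccc(C)cc4)cc3)sc2c1` gives 34000 nM in an ADME assay on MCF-10A cells (Homo sapiens) for cytotoxicity, read by MTT assay, with a stated time of 72 h; a higher number here means a weaker inhibitor, a lower number a stronger inhibitor. The two other measured compounds sit close by: compound 1 `COc1ccc(-c2ccc(C)n2-c2ccc(-c3nc4ccccc4s3)cc2)cc1` gives 36300 nM in this assay, and compound 2 `COc1ccc(-c2ccc(C)n2-c2ccc(-c3nc4ccc(F)cc4s3)cc2)cc1` gives 37800 nM; compound 3 is within the scatter of both, so nothing separates the three on this read-out. Going by the values given here, the one single-point step available, a 1.0-fold higher number from compound 1 to compound 2 (0.02 log units; within the scatter), is within the scatter.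

Compound 4 `COc1ccc(-c2ccc(C)n2-c2ccc(-c3nc4ccc(OC)cc4s3)cc2)cc1` differs from compound 3 by methoxy in place of methyl on an aromatic carbon. Among the compounds with values here, no measured step swaps methoxy for methyl, so the only comparison that bears on it is the fluoro-for-hydrogen step, a 1.0-fold higher number from compound 1 to compound 2 (0.02 log units; within the scatter), and that step shows no movement beyond the scatter; it is an indirect guide only. Given that, and the flat spread across compounds 1, 2 and 3, the expected step of a 1.0-fold higher number from compound 3 to compound 4 (0.01 log units; within the scatter) is none beyond the scatter. Compound 4 is therefore estimated at 35000 nM in this assay, with a range from 18000 nM to 70000 nM.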

Compound 4, half-maximal inhibitory concentration: 30600 nM
Compound 4: middle estimate off by 1.1-fold (0.06 log units), on the high side; the range from low to high includes it.
By their numbers in this assay, from the lowest: compounds 4, 3, 1 and 2 (each within the scatter of the next).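

At the carbon para to a large group, 4-methylphenyl to 4-methoxyphenyl gives a 1.1-fold lower number from compound 3 to compound 4 (0.05 log units; within the scatter) in this assay, so a second position of the series, one that the earlier step did not touch, also shows no movement beyond the scatter. At the carbon that carries fluoro in compound 2, methoxy gives a 1.2-fold lower number from compound 2 to compound 4 (0.09 log units; within the scatter) and, in place of hydrogen, a 1.2-fold lower number from compound 1 to compound 4 (0.07 log units; within the scatter), so hydrogen, fluoro and methoxy are not told apart there. Nothing available accounts for this flat picture.

The compounds shown leave open whether an amine or a carboxylic acid on either of these aromatic carbons would move the number beyond the scatter in this assay. They also leave open what a longer chain in place of methoxy would do.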